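Nitro in place of hydrogen on the aromatic ring

A few compounds are considered here, and "the series" means these few. Any claim that something is new, unique, unknown or untested is made for them only; others in the source may bear on it.

Compound 1 `Cn1cc(C(=O)c2ccccc2)cc1/C=C/C(=O)NO` stands highest of the two measured compounds in an assay on isolated protein for inhibition of histone deacetylase HD2 (Zea mays), tested at 30 uM; a higher number here means more inhibition at the concentration tested (going by the name of the read-out), a lower number less inhibition: compound 1 gives 86%. Compound 2 `COc1ccc(C(=O)c2cc(/C=C/C(=O)NO)n(C)c2)cc1` carries a methoxy in place of hydrogen on an aromatic carbon, and in this assay compound 2 gives 75.2%, so that a number 10.8 percentage points lower from compound 1 to compound 2 (beyond the scatter). Compound 3 `Cn1cc(C(=O)c2ccc([N+](=O)[O-])cc2)cc1/C=C/C(=O)NO` differs from compound 1 in one place: nitro in place of hydrogen on an aromatic carbon. Within the data shown here, the only measured step that bears on this change is the one from compound 1 to compound 2, where another group entered at the same kind of position and the number fell modestly. With a single step to go by and a different entering group, compound 3 is expected to remain close to compound 1 in this assay, allowing for a small to modest decrease, a number 7 percentage points lower from compound 1 to compound 3 (within the scatter). Compound 3 is therefore estimated at 79%, in a range from 64% to 92%.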

Compound 3, a percentage reported as inhibition, at one concentration (the size of the read-out at that concentration, not a potency): 78%
The estimate for compound 3 lay 1 percentage points above the measured number, and the stated range covers the measured number.
By their numbers in this assay, from the lowest: compounds 2, 3 and 1 (each within the scatter of the next, the first and the last beyond it).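

In this assay, nitro on the aromatic carbon para to a large group gives a number 8 percentage points lower from compound 1 to compound 3 (within the scatter) and so cannot be told apart from the hydrogen of compound 1. Set against methoxy at the same place, it gives a number 2.8 percentage points higher from compound 2 to compound 3 (within the scatter) and cannot be told apart from that group either. This place therefore takes a nitro group of 3 heavy atoms without a step beyond the scatter, and compound 3 lies within the scatter of both neighbours even though those two differ beyond it. Nothing available bears on why the numbers fall as they do. On these data alone, whether an amine or a carboxylic acid at this place would stay within the scatter of compound 1 remains open, as does how a halogen such as chlorine would read there.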